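The compounds below may be only part of what the source reports. "The series", "measured", "known", "first", "only" and "open" are said of these compounds alone.

Notes on the series in a functional assay on HCT-116 cells (Homo sapiens) for inhibition, read by sulforhodamine B assay, with a stated time of 48 h; a higher number here means that more compound is tolerated, a lower number that less compound is tolerated. Compound 1 `COc1cc(-c2nn(-c3cccc(NC(=O)Nc4ccc(Cl)c(Cl)c4)c3)cc2-c2ccncc2)ccc1Cl` sits at > 50000 nM, which is a limit of the assay and not a number. Compound 2 `O=C(Nc1cccc(-n2cc(-c3ccncc3)c(-c3ccc(Cl)c(O)c3)n2)c1)Nc1ccc(Cl)c(Cl)c1` sits at > 32500 nM, again a limit rather than a measured number. Compound 3 `COc1cc(-c2nn(-c3cccc(NC(=O)c4ccc(Cl)c(C(F)(F)F)c4)c3)cc2-c2ccncc2)ccc1Cl` sits at > 32500 nM, a limit as well. Compound 2 therefore stands on a limit, and the two other values shown in this assay are limits too. The step that the two limits leave unreadable from compound 1 to compound 2 and the step that the two limits leave unreadable from compound 1 to compound 3 have no readable size because both ends rest on the limit of > 32500 nM in this assay, at which 2 of the 3 values shown sit, or (the limit of > 50000 nM in this assay, at which 1 of the 3 values shown sits).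

Compound 4 `O=C(Nc1cccc(-n2cc(-c3ccncc3)c(-c3ccc(Cl)c(O)c3)n2)c1)Nc1ccc(Cl)c(C(F)(F)F)c1` differs from compound 2 by trifluoromethyl in place of chloro on an aromatic carbon. Among the compounds with values here, the only measured step that touches this exchange is a step that the two limits leave unreadable from compound 1 to compound 3, which carries it together with a further change and is itself unreadable. Within the data shown here, no measured step in this assay bears on the move with a readable size, so nothing beyond the scatter is predicted in either direction, and a result at a limit is the likeliest outcome. The expected step is a step that the limit leaves unreadable from compound 2 to compound 4. Compound 4 is estimated at 40000 nM, with a range from 15000 nM to 100000 nM.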

Compound 4, concentration lethal to 50% of the cells: > 32500 nM
Compound 4 ended at the assay's limit (the forecaster's own chance of this, stated with the estimate: 80%); the middle value lies beyond the limit too.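

No step can be read from compound 2 to compound 4, because both values rest on a limit of the assay and neither is a number: the limit of > 32500 nM in this assay, at which 3 of the 4 values shown sit.

The compounds shown leave open how far any of these changes, trifluoromethyl in place of chloro on an aromatic carbon included, moves the lethal concentration; all four values are limits.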